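From 4-hydroxyphenyl to 4-bromophenyl on the shared core

The source may hold more compounds than are shown below. What is called first, only, known or untested is meant among the compounds shown, and "the series" means these compounds.

In a functional assay on OVCAR-3 cells (Homo sapiens) for inhibition, read by MTT assay, with a stated time of 24 h (on this read-out lower numbers stand for stronger inhibition and higher numbers for weaker inhibition), compound 1 (`CC1(C)[C@H]2CC[C@]1(C)N(Cc1cn(-c3cccc(F)c3)nn1)C(=O)C2`) gives 430 nM, compound 2 (`CC1(C)[C@H]2CC[C@]1(C)N(Cc1cn(-c3ccccc3C#N)nn1)C(=O)C2`) gives 110 nM and compound 3 (`CC1(C)[C@H]2CC[C@]1(C)N(Cc1cn(-c3ccc(O)cc3)nn1)C(=O)C2`) gives 410 nM. Compound 3 therefore sits level with compound 1, as a 1.0-fold lower number from compound 1 to compound 3 (0.02 log units; within the scatter) shows, while a 3.7-fold higher number from compound 2 to compound 3 (0.57 log units; beyond the scatter) places it clearly above compound 2.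

The next compound is compound 4 (`CC1(C)[C@H]2CC[C@]1(C)N(Cc1cn(-c3ccc(Br)cc3)nn1)C(=O)C2`), with the change bromo in place of hydroxy on an aromatic carbon, para to a large group. For the measured compounds named here, no measured step makes this exact exchange, so the evidence is indirect. Among the three aryl exchanges, a 1.0-fold lower number from compound 1 to compound 3 (0.02 log units; within the scatter) is the only one involving the 4-hydroxyphenyl and a halogen-bearing aryl group, and it stays within the scatter. The larger steps, a 3.9-fold lower number from compound 1 to compound 2 (0.59 log units; beyond the scatter) and a 3.7-fold higher number from compound 2 to compound 3 (0.57 log units; beyond the scatter), both involve the 2-cyanophenyl of compound 2, which is absent here. The expected step is a 1.2-fold lower number from compound 3 to compound 4 (0.07 log units; within the scatter), with no change beyond the scatter anticipated. For compound 4 the estimate is 350 nM, within an expected range of 130 nM to 900 nM.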

Compound 4, half-maximal inhibitory concentration: 140 nM
Estimate against measurement, compound 4: 2.5-fold (0.40 log units) above, and the stated range covers the measured number.
By their numbers in this assay, from the lowest: compounds 2 and 4 (each within the scatter of the next); then compounds 3 and 1 (each within the scatter of the next).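

Replacing hydroxy with bromo, para to a large group, moves the number beyond the scatter (a 2.9-fold lower number from compound 3 to compound 4 (0.47 log units; beyond the scatter)), so a change on the aryl group can matter here without the 2-cyanophenyl group being involved. The 4-bromophenyl group also reads level with the 2-cyanophenyl group (a 1.3-fold higher number from compound 2 to compound 4 (0.10 log units; within the scatter)) and stands clearly apart from the 3-fluorophenyl group (a 3.1-fold lower number from compound 1 to compound 4 (0.49 log units; beyond the scatter)), which means that compound 2 no longer stands alone at the low end of the series. No supporting data are available to explain the difference between hydroxy and bromo.

As far as these compounds go, whether this shift is specific to bromo remains open: chloro, iodo, methyl, an amine or a carboxylic acid at the same place would help to settle it. From the compounds shown here alone, what bromo does at another place on the phenyl ring also remains open.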